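Replacing chloro with methoxy: notes on the series

This account rests on a few compounds, and the source may have more. Where it says the series, first, only, none or still open, it means among the compounds named here.

Of the compounds shown here, three have numbers so far in a functional assay on NUGC cells (Homo sapiens) for cytotoxicity; a lower number here means a stronger inhibitor, a higher number a weaker inhibitor. Compound 3 `O=C1C=CC[C@H]([C@@H](O)[C@H](Cl)c2ccccc2)O1` gives 31 ug/mL, within the scatter of compound 1 `O=C1C=CC[C@H]([C@@H]2O[C@H]2c2ccccc2)O1` at 32.1 ug/mL. Compound 2 `CC(=O)O[C@H]([C@H](O)c1ccccc1)[C@H]1CC=CC(=O)O1` gives 4.12 ug/mL, a lower number than compound 3, with the gap beyond the scatter. Compound 4 `CO[C@H](c1ccccc1)[C@H](O)[C@H]1CC=CC(=O)O1` differs from compound 3 by methoxy in place of chloro on a saturated chain carbon bound to an aromatic carbon and a saturated chain carbon. Going by the values given here, no measured pair isolates this change. Among the compounds with values here, the only guide is that compound 2 at 4.12 ug/mL shows lower numbers occur in this small set. The step expected is a 2.6-fold lower number from compound 3 to compound 4 (0.41 log units; beyond the scatter), towards a lower number. For compound 4 the estimated value is 12 ug/mL, with an expected range of 3.5 ug/mL to 40 ug/mL.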

Compound 4, half-maximal inhibitory concentration: 168 ug/mL
Compound 4: middle estimate off by 14-fold (1.15 log units), on the low side, and the stated range ends below it.
By their numbers in this assay, from the lowest: compound 2; then compounds 3 and 1 (each within the scatter of the next); then compound 4.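

In this assay, methoxy in place of chloro on a saturated chain carbon bound to an aromatic carbon and a saturated chain carbon gives a 5.4-fold higher number from compound 3 to compound 4 (0.73 log units; beyond the scatter) and so shows that the number responds to the group at this position. This first single-place step in the series runs towards a weaker inhibitor, away from the lower number of compound 2. Going by these compounds alone, nothing measured so far accounts for the step.

On these data alone, whether the rise is particular to methoxy remains open. An amine or ethoxy on this carbon would test how far the trend extends.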